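The source may hold more compounds than are shown below. What is called first, only, known or untested is meant among the compounds shown, and "the series" means these compounds.

Measured compounds:
Compound 1, `COc1ccc2nc(-c3ccc(N/C=C\C(=O)c4ccc(OC)c(F)c4)cc3)sc2c1`: 1300 nM in a functional assay on MIA PaCa-2 cells (Homo sapiens) for antiproliferative activity, read by sulforhodamine B assay, with a stated time of 48 h; on this read-out lower numbers stand for stronger inhibition and higher numbers for weaker inhibition
Compound 2, `COc1ccc2nc(-c3ccc(N/C=C\C(=O)c4ccc(OC)c([N+](=O)[O-])c4)c(C)c3)sc2c1`: 23600 nM
Compound 3, `COc1ccc2nc(-c3ccc(N/C=C\C(=O)c4cc(OC)c(OC)c([N+](=O)[O-])c4)c(C)c3)sc2c1`: 12000 nM

Compound 3 stands second highest of the three numbers in this assay. Its nearest neighbour is compound 2, and the step of a 2.0-fold lower number from compound 2 to compound 3 (0.29 log units; within the scatter) is within the scatter, while compound 1 lies well apart with the lowest number of the three. Compound 4, `COc1ccc2nc(-c3ccc(N/C=C\C(=O)c4cc(OC)c(OC)c([N+](=O)[O-])c4)cc3)sc2c1`, is the compound still to be measured. Relative to compound 3 it differs by hydrogen in place of methyl on an aromatic carbon. Within the data shown here, no measured step makes this same change on its own: the only measured step, a 2.0-fold lower number from compound 2 to compound 3 (0.29 log units; within the scatter), concerns a methoxy group and is a different change altogether. Compound 1 carries hydrogen at the same place as compound 4 and shows the lowest number, yet it also differs from compound 3 elsewhere, so it does not isolate the change. On this thin footing compound 4 is expected to show a 2.0-fold lower number from compound 3 to compound 4 (0.30 log units; within the scatter), a modest move towards a lower number that may not exceed the scatter. The estimate for compound 4 is 6000 nM in this assay, with a range from 2000 nM to 20000 nM.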

Compound 4, half-maximal inhibitory concentration: 25600 nM
Beside the measured number, compound 4's estimate is 4.3-fold (0.63 log units) below it, and the stated range ends below it.
By their numbers in this assay, from the lowest: compound 1; then compounds 3, 2 and 4 (each within the scatter of the next, the first and the last beyond it).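

Within this assay the exchange of methyl for hydrogen gives a 2.1-fold higher number from compound 3 to compound 4 (0.33 log units; beyond the scatter) and this is the first step that isolates this position, on an aromatic carbon, ortho to a large group and meta to a 6-methoxy-1,3-benzothiazol-2-yl group. In this one pair, the compound keeping the methyl group has the lower number, so removing the methyl group brings no gain and costs a modest amount of inhibition. Nothing available explains why this small change moves the number in this direction.

Going by these compounds, whether an ethyl group, a chlorine atom or an amine at this position would give a lower number than methyl remains open. Also open, on these data alone, is whether methyl has the same effect when the methoxy and nitro groups on the other aromatic ring are replaced, for example by the fluorine of compound 1.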